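From ethylamino to phenoxy on the shared core

This account rests on a few compounds, and the source may have more. Where it says the series, first, only, none or still open, it means among the compounds named here.

Compounds measured so far in an ADME assay (liver) for metabolic stability, with Liver microsome (Rattus norvegicus) as the target, using microsomes and NADPH, with a stated time of 30 min, at 37 degrees C, tested at 1 uM; a lower number here means slower removal, a higher number faster removal of the compound (intrinsic clearance in microsomes):

Compound 1 `CC(O)(c1ccc(-c2ccc(S(=O)(=O)c3ccc(N)nc3)cc2)cc1)C(F)(F)F` gives < 14 mL.min-1.g-1
Compound 2 `C[C@H](O)C#Cc1cc(C(O)(C(F)(F)F)C(F)(F)F)cnc1-c1ccc(S(=O)(=O)c2ccc(N)nc2)cc1` gives 29 mL.min-1.g-1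
Compound 3 `CCNc1nc(S(=O)(=O)c2ccc(N)nc2)ccc1-c1ccc(C(C)(O)C(F)(F)F)cn1` gives 42 mL.min-1.g-1

The value of compound 1 is a limit of the assay and not a number. Compound 3 and compound 2 lie within the usual scatter of each other, so this assay does not separate them.

Compound 4 `CC(O)(c1ccc(-c2ccc(S(=O)(=O)c3ccc(N)nc3)nc2Oc2ccccc2)nc1)C(F)(F)F` has phenoxy in place of ethylamino on an aromatic carbon, next to the ring nitrogen and ortho to a large group (phenoxy in place of ethylamino on an aromatic carbon). Within the data shown here, no measured pair here differs in one place only, so the data give no direct measure of this change. On these data alone, no step beyond the scatter is expected in this assay, and the direction remains open. The expected size of the change is a 1.1-fold higher number from compound 3 to compound 4 (0.03 log units; within the scatter), an estimate that starts from compound 3 at 42 mL.min-1.g-1. For compound 4 the estimated value is 45 mL.min-1.g-1, with an expected range from 18 mL.min-1.g-1 to 110 mL.min-1.g-1.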

Compound 4, intrinsic clearance in microsomes: 213 mL.min-1.g-1
The estimate for compound 4 lay 4.7-fold (0.68 log units) below the measured number; measured number outside the range, above it.
By their numbers in this assay, from the lowest: compounds 2 and 3 (each within the scatter of the next); then compound 4. At a limit, below all of these: compound 1.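

In this assay, the aromatic carbon next to the ring nitrogen and ortho to a large group proves sensitive to the group it carries: phenoxy in place of ethylamino gives a 5.1-fold higher number from compound 3 to compound 4 (0.71 log units; beyond the scatter). Among these compounds, the earlier compounds included no pair differing in one place, so this is the first direct reading of a change at any position, and it lies beyond the scatter. No measurement shown bears on why the number rises.

One step cannot separate the entry of the aromatic ring from the exchange of the nitrogen link for an oxygen link or the departure of the ethyl chain. On these data alone, whether methoxy or anilino on this carbon would fall near compound 3 or near compound 4 remains open, as does whether the step carries over to other cores.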